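The source may hold more compounds than are shown below. What is called first, only, known or untested is meant among the compounds shown, and "the series" means these compounds.

Compound 1 `O=C(NC1CCN(Cc2ccn(-c3ccc(C(F)(F)F)cc3)c2)CC1)N1CCCC1Cc1cccnc1` gives 26 nM in an assay on HEK293 cells for displacement of a labelled ligand from melanin-concentrating hormone receptor 1 (Homo sapiens); a lower number here means a stronger inhibitor, a higher number a weaker inhibitor.
Compound 2 `COc1ccc(OC2CN(C(=O)NC3CCN(Cc4ccn(-c5ccc(C(F)(F)F)cc5)c4)CC3)C2)cc1` gives 49 nM in this assay.
Compound 3 `O=C(NC1CCN(Cc2ccn(-c3ccc(C(F)(F)F)cc3)c2)CC1)N1CCCCC1CCO` gives 39 nM in this assay.

The three numbers lie close together. Compound 3 sits within the usual scatter of compound 1 on one side and of compound 2 on the other, so none of the three can be called stronger or weaker than another on these data. Among the compounds with values here, the one single-point step that has been measured, a 1.5-fold higher number from compound 1 to compound 3 (0.18 log units; within the scatter), changes the group on the carbonyl carbon and leaves the number essentially where it was.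

Compound 4 `O=C(NC[C@H]1CCCC[C@H]1O)NC1CCN(Cc2ccn(-c3ccc(C(F)(F)F)cc3)c2)CC1` is built from the same atoms as compound 3, joined differently: ((2-hydroxycyclohexyl)methyl)amino in place of 2-(2-hydroxyethyl)piperidin-1-yl on a carbonyl carbon. Within the data shown here, the only measured step at this place, the one from compound 1 to compound 3, stayed within the scatter, which suggests that this carbonyl carbon tolerates rather different groups. Among the measured compounds shown here, nothing measured so far, however, touches a change in which the ring nitrogen is exchanged for a ring of carbon only with an extra hydrogen-bond donor, so the expectation is held loosely. A step of a 1.5-fold higher number from compound 3 to compound 4 (0.19 log units; within the scatter) is expected in this assay, close to no change. Compound 4 is estimated at 60 nM, with a range from 20 nM to 200 nM.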

Compound 4, half-maximal inhibitory concentration: 63 nM
Estimate against measurement, compound 4: 1.1-fold (0.02 log units) below, within the range that was stated.
By their numbers in this assay, from the lowest: compounds 1, 3, 2 and 4 (each within the scatter of the next, the first and the last beyond it).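

In this assay, joining the same atoms differently gives a 1.6-fold higher number from compound 3 to compound 4 (0.21 log units; within the scatter): the step stays within the scatter, so on this pair, a six-membered non-aromatic ring of carbon only, with 2 hydrogen-bond donors in ((2-hydroxycyclohexyl)methyl)amino where 2-(2-hydroxyethyl)piperidin-1-yl has 1, is accommodated on this carbonyl carbon. Within the data shown here, the other comparison with the same entering group, a 2.4-fold higher number from compound 1 to compound 4 (0.38 log units; beyond the scatter), is the first step at this place to pass beyond the scatter, though only modestly, so the tolerance seen earlier at this carbonyl carbon holds across wide changes of group but is not complete. Nothing available accounts for either step.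

The compounds shown leave open what the hydroxy group of ((2-hydroxycyclohexyl)methyl)amino contributes, since no partner carries a methoxy group, an amine or a bare hydrogen there. They also leave open whether another arrangement of its 2 defined stereocentres would read the same in this assay, and whether a longer chain between the ring and the amide nitrogen would keep the number where it stands.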